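The compounds below may be only part of what the source reports. "The series", "measured", "known", "first", "only" and "open" are said of these compounds alone.

Working notes on the series. In an assay for inhibition of Catechol O-methyltransferase (Rattus norvegicus), read by fluorescence and spectrophotometry (a higher number here means a weaker inhibitor, a lower number a stronger inhibitor), compound 1 `CC(=O)N1N=C(c2cc(O)c(O)c([N+](=O)[O-])c2)CC1c1ccco1` gives 180 nM. Compound 2 `O=C(/C=C/c1cccs1)c1cc(O)c(O)c([N+](=O)[O-])c1` gives in this assay 190 nM; the two numbers are within the scatter of each other, so compound 1 cannot be set apart from compound 2 on these data. Compound 3 `CC(=O)N1N=C(c2cc(O)c(O)c([N+](=O)[O-])c2)CC1c1cccs1` is not yet measured. It differs from compound 1 by thiophen-2-yl in place of furan-2-yl on a saturated ring carbon. Going by the values given here, no measured pair shows this change, so no step beyond the scatter is expected in either direction. For compound 3 the expected step is no change at the digits printed from compound 1 to compound 3 (within the scatter), giving an estimate of 180 nM with a range from 80 nM to 400 nM.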

Compound 3, half-maximal inhibitory concentration: 210 nM
Compound 3: the middle estimate sits 1.2-fold (0.07 log units) below what was measured; low and high end bracket the measured number.
By their numbers in this assay, from the lowest: compounds 1, 2 and 3 (each within the scatter of the next).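

In this assay, going by these compounds alone, thiophen-2-yl in place of furan-2-yl on the saturated ring carbon gives a 1.2-fold higher number from compound 1 to compound 3 (0.07 log units; within the scatter), the first direct reading of this change at this position. This pair therefore does not separate the two five-membered aromatic rings at this carbon. No measured evidence bears on this result.

The compounds shown leave open how the series responds at this carbon to a group other than these two rings, such as a phenyl ring, an amine or a carboxylic acid.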